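Shifting the hydroxyl on one flanking aryl of the core

This account rests on a few compounds, and the source may have more. Where it says the series, first, only, none or still open, it means among the compounds named here.

Compound 1 `Oc1cccc(-c2cc(-c3ccc(F)cc3)cc(-c3ccccc3O)n2)c1` sits at the limit of a functional assay on HCT-15 cells (Homo sapiens) for inhibition (on this read-out higher numbers stand for weaker inhibition and lower numbers for stronger inhibition), where it gives > 50000 nM. Among the measured compounds shown here, compound 2 `Oc1cccc(-c2cc(-c3cccc(C(F)(F)F)c3)cc(-c3ccccc3O)n2)c1` gives 6460 nM and is the only member of the set with a number rather than a limit. Compound 3 `Oc1cccc(-c2cc(-c3ccc(C(F)(F)F)cc3)cc(-c3ccccc3O)n2)c1` again returns a limit, > 50000 nM. The measured steps all concern the trifluoromethyl-bearing ring: an at least 7.7-fold lower number from compound 1 to compound 2 (0.88 log units; beyond the scatter), an at least 7.7-fold higher number from compound 2 to compound 3 (0.88 log units; beyond the scatter), while a step that the two limits leave unreadable from compound 1 to compound 3 because both values rest on (the limit of > 50000 nM in this assay, at which 2 of the 3 values shown sit).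

Compound 4 `Oc1ccc(-c2cc(-c3ccc(C(F)(F)F)cc3)cc(-c3cccc(O)c3)n2)cc1` keeps that ring as in compound 3 and alters the other flank: 4-hydroxyphenyl in place of 2-hydroxyphenyl on an aromatic carbon. For the measured compounds named here, none of the measured steps touches the hydroxyl position on this ring, so no measured step bears directly on the change. Compound 3 is anchored only by a limit, so the step can be read in one direction alone, and the expectation for compound 4 is that this assay again reports a limit or a number close to it. Compound 4 is therefore estimated at 50000 nM in this assay, with a range from 20000 nM to 120000 nM, which means a number no higher from compound 3 to compound 4 (the limit leaves the size open) is expected, that is, no step beyond the scatter.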

Compound 4, half-maximal inhibitory concentration: 6440 nM
Compound 4: the middle estimate sits 7.8-fold (0.89 log units) above what was measured; the whole stated range lies above it.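

In this assay, moving the hydroxyl on this flank gives an at least 7.7-fold lower number from compound 3 to compound 4 (0.89 log units; beyond the scatter), so the flank next to the ring nitrogen can carry a change that is readable on its own, whereas every earlier step concerned the trifluoromethyl-bearing ring while the 2-hydroxyphenyl stayed fixed. The result also shows that the 4-(trifluoromethyl)phenyl group does not by itself tie the series to the assay limit, since compound 4 keeps that group and still returns a number. Compound 3 stands at a limit and not at a number, so the step has a lower bound only and its full size stays open: the limit of > 50000 nM in this assay, at which 2 of the 4 values shown sit.

Still open, on these data alone, is whether 4-hydroxyphenyl in place of 2-hydroxyphenyl gives a similar step when 3-(trifluoromethyl)phenyl or 4-fluorophenyl sits on the shared core, as compound 4 differs from compound 1 and compound 2 in more than one place and cannot be read against them. The compounds shown also leave open whether the hydroxyl itself is needed on this flank, or whether a methoxy group, an amine or a carboxylic acid at the same ring position would serve in its place.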